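The source may hold more compounds than are shown below. What is called first, only, known or untested is meant among the compounds shown, and "the series" means these compounds.

Compound 1, whose structure is `COc1cc(-c2cc(/C=C/C(=O)c3ccc(N)cc3)[nH]n2)cc(OC)c1OC`, is one of three compounds tested in a functional assay on MDA-MB-468 cells (Homo sapiens) for cytotoxicity, read by sulforhodamine B assay, with a stated time of 48 h, tested at 1 uM; on this read-out lower numbers stand for a stronger effect and higher numbers for a weaker effect at the one concentration tested. In this assay compound 1 gives 50%, the lowest of the three numbers. Compound 2, `COc1ccc(-c2cc(/C=C/C(=O)c3ccc(N)cc3)[nH]n2)cc1OC`, gives 77%, and compound 3, `COc1ccc(-c2cc(/C=C/C(=O)c3cc(OC)c(OC)c(OC)c3)[nH]n2)cc1OC`, gives 66%. Among the measured compounds shown here, the only single-point step among them, a number 27 percentage points higher from compound 1 to compound 2 (beyond the scatter), comes from hydrogen in place of methoxy on an aromatic carbon.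

Compound 4, `COc1ccc(C(=O)/C=C/c2cc(-c3cc(OC)c(OC)c(OC)c3)n[nH]2)cc1`, differs from compound 1 as follows: methoxy in place of amino on an aromatic carbon. For the measured compounds named here, no measured step touches this part of the shared core, since the one step seen concerns a methoxy elsewhere and compound 3 differs from compound 1 in more than one place. The weakening seen in the step from compound 1 to compound 2 and the higher number of compound 3 suggest that changes away from compound 1 tend toward weaker effect, so a small weakening, possibly within the scatter, is expected as a number 12 percentage points higher from compound 1 to compound 4 (beyond the scatter). Compound 4 is therefore estimated at 62%, within a range from 45% to 80%.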

Compound 4, a percentage reported as activity, at one concentration (the size of the read-out at that concentration, not a potency): 68%
The estimate for compound 4 lay 6 percentage points below the measured number; the measured number falls inside the stated range.
By their numbers in this assay, from the lowest: compound 1; then compounds 3, 4 and 2 (each within the scatter of the next, the first and the last beyond it).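

Replacing 4-aminophenyl with 4-methoxyphenyl gives a number 18 percentage points higher from compound 1 to compound 4 (beyond the scatter) in this assay, so at this spot, para to a large group, methoxy does not stand in for amino without a weaker effect. This is the first measured single change at this end of the molecule, and alongside a number 27 percentage points higher from compound 1 to compound 2 (beyond the scatter) at the other end, it means that both single changes shown from compound 1 weaken the effect. No evidence is available to say what lies behind this difference.

Going by these compounds, it remains open whether a hydroxyl or a dimethylamino group in the same place would match amino or fall closer to methoxy. Also open, on these data alone, is whether the step would keep its size at other concentrations, as all of these numbers come from a single tested concentration.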